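The source may hold more compounds than are shown below. What is called first, only, known or untested is meant among the compounds shown, and "the series" means these compounds.

Going by the values given here, in a functional assay on NCI-H460 cells (Homo sapiens) for cytotoxicity, read by MTT assay, with a stated time of 72 h (on this read-out higher numbers stand for weaker inhibition and lower numbers for stronger inhibition), compound 3 `CC(C)(C)C1=CC(=O)C=CC1=O` gives 72000 nM, the highest of the three numbers so far and therefore the weakest inhibition among them. Compound 2 `CNC1=CC(=O)C=C(C(C)(C)C)C1=O` gives 23000 nM, and compound 1 `CCCCNC1=CC(=O)C=C(C(C)(C)C)C1=O` gives 13000 nM. Compound 4 `CCNC1=CC(=O)C=C(C(C)(C)C)C1=O` has not yet been measured. It differs from compound 3 by ethylamino in place of hydrogen on a double-bonded ring carbon, with ethylamino in place of hydrogen on a double-bonded ring carbon.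

Two measured steps make a similar change at that carbon. With methylamino, the step is a 3.1-fold higher number from compound 2 to compound 3 (0.50 log units; beyond the scatter), and with butylamino, it is a 5.5-fold higher number from compound 1 to compound 3 (0.74 log units; beyond the scatter). Both are modest, and both show compound 3 with the higher number. Chain length offers little further guidance, since a 1.8-fold higher number from compound 1 to compound 2 (0.25 log units; within the scatter) stays within the scatter. Ethylamino is longer than methylamino and shorter than butylamino, so a modest move to a lower number is expected in this assay. The expected size of the change is a 4.0-fold lower number from compound 3 to compound 4 (0.60 log units; beyond the scatter). For compound 4, the estimated value is 18000 nM, with an expected range of 9000 nM to 36000 nM.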

Compound 4, half-maximal inhibitory concentration: 14000 nM
Compound 4: middle estimate off by 1.3-fold (0.11 log units), on the high side, within the range that was stated.
By their numbers in this assay, from the lowest: compounds 1, 4 and 2 (each within the scatter of the next); then compound 3.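

In this assay, placing ethylamino on the double-bonded ring carbon gives a 5.1-fold lower number from compound 3 to compound 4 (0.71 log units; beyond the scatter), so ethylamino joins methylamino and butylamino in standing apart from compound 3 by more than the scatter. The chain length does not separate these three amines: adding one methyl to the chain gives a 1.6-fold lower number from compound 2 to compound 4 (0.22 log units; within the scatter), and replacing the far ethyl end of the butyl chain with hydrogen gives a 1.1-fold higher number from compound 1 to compound 4 (0.03 log units; within the scatter), both within the scatter. Across these compounds, having an alkylamino group at this position matters more than whether its chain is methyl, ethyl or butyl.

Still open, going by these compounds, is whether a much longer chain, such as octyl, or a ring amine, such as morpholine, would fit the same picture. Nothing measured here explains why the amines give lower numbers than hydrogen.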